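Replacing the sulfur-linked triazole with a phenylpiperazine

The source may hold more compounds than are shown below. What is called first, only, known or untested is meant among the compounds shown, and "the series" means these compounds.

Compound 1 `Cn1c(-c2ccc(NC(=O)CSc3nc4ccccc4s3)cc2)nc(-c2ccccc2)c1-c1ccccc1`: 9.8%
Compound 2 `Cn1cnnc1SCC(=O)Nc1ccc(-c2nc(-c3ccccc3)c(-c3ccccc3)n2C)cc1`: 32%
Compound 3 `Cn1ccnc1SCC(=O)Nc1ccc(-c2nc(-c3ccccc3)c(-c3ccccc3)n2C)cc1`: 13.6%

In a functional assay on HT-29 cells (Homo sapiens) for cytotoxicity, read by MTT assay, with a stated time of 24 h, tested at 0.64 ug/mL (a higher number here means a stronger effect of the compound at the concentration tested, a lower number a weaker effect), compound 2 gives 32%, the highest of the three numbers. Its nearest neighbour is compound 3, reached by a number 18.4 percentage points lower from compound 2 to compound 3 (beyond the scatter), and the furthest is compound 1, from which a number 22.2 percentage points higher from compound 1 to compound 2 (beyond the scatter). The step of a number 3.8 percentage points higher from compound 1 to compound 3 (within the scatter) stays within the scatter.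

Compound 4 `Cn1c(-c2ccc(NC(=O)CN3CCN(c4ccccc4)CC3)cc2)nc(-c2ccccc2)c1-c1ccccc1` differs from compound 2 by 4-phenylpiperazin-1-yl in place of (4-methyl-4H-1,2,4-triazol-3-yl)sulfanyl on a saturated chain carbon bound to a carbonyl carbon. For the measured compounds named here, no measured step touches this change: all three measured compounds keep the sulfur link, and none carries a piperazine. The two steps that leave compound 2, a number 22.2 percentage points higher from compound 1 to compound 2 (beyond the scatter) and a number 18.4 percentage points lower from compound 2 to compound 3 (beyond the scatter), show that exchanging the group on the sulfur alone shifts the read-out beyond the scatter, in both directions, so the substituent on the chain carbon clearly matters, but its direction for a group of this new kind cannot be read from the data.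

In this assay compound 4 is therefore expected to give about 18%, within a wide range of 5% to 40%, which is an estimated step of a number 14 percentage points lower from compound 2 to compound 4 (beyond the scatter).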

Compound 4, a percentage reported as activity, at one concentration (the size of the read-out at that concentration, not a potency): 17.3%
Compound 4: the middle estimate sits 0.7 percentage points above what was measured, and the stated range covers the measured number.
By their numbers in this assay, from the lowest: compounds 1, 3 and 4 (each within the scatter of the next); then compound 2.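

In this assay the change from the triazole-bearing group to 4-phenylpiperazin-1-yl on a saturated chain carbon bound to a carbonyl carbon is a number 14.7 percentage points lower from compound 2 to compound 4 (beyond the scatter) and thus does not keep the read-out of the triazole compound. The two other steps, a number 3.7 percentage points higher from compound 3 to compound 4 (within the scatter) and a number 7.5 percentage points higher from compound 1 to compound 4 (within the scatter), separate nothing, so a group with no sulfur and with a non-aromatic ring stands level with (1-methyl-1H-imidazol-2-yl)sulfanyl and (1,3-benzothiazol-2-yl)sulfanyl, and among the four groups shown at this place only (4-methyl-4H-1,2,4-triazol-3-yl)sulfanyl stands apart. Nothing available gives a reason for this separation of the triazole compound from the other three.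

The compounds shown leave open whether the read-out of compound 2 belongs to the triazole ring alone or to the ring together with its sulfur link, which an oxygen atom in that link would test. They also leave open what the phenyl on the piperazine contributes, which a 4-methylpiperazin-1-yl group or a morpholine on the same chain carbon would separate.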